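This account rests on a few compounds, and the source may have more. Where it says the series, first, only, none or still open, it means among the compounds named here.

Values so far in an ADME assay on CCRF-CEM cells (Homo sapiens) for antiproliferative activity, with a stated time of 48 h; a lower number here means a stronger inhibitor, a higher number a weaker inhibitor:
- compound 1 `C=C(Br)C(=O)Nc1ccc(/C=C/C(=O)c2cccc(OC)c2)cc1` gives 2300 nM
- compound 2 `Nc1ccc(/C=C/C(=O)c2ccccc2)cc1` gives 34000 nM

Compound 2 holds the higher number of the two, and its gap to compound 1 lies beyond the scatter. Among the compounds with values here, compound 3 `COc1cccc(C(=O)/C=C/c2ccc(N)cc2)c1` is compound 2 with methoxy in place of hydrogen on an aromatic carbon as the one change: methoxy in place of hydrogen on an aromatic carbon. Within the data shown here, no measured pair isolates this change, since compound 1 also carries methoxy but differs in a second place. Expected is a 2.1-fold lower number from compound 2 to compound 3 (0.33 log units; beyond the scatter) toward a lower number, modest and close to the size of the scatter. For compound 3 the estimate is 16000 nM with an expected range from 4000 nM to 50000 nM once measured.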

Compound 3, half-maximal inhibitory concentration: 26000 nM
Estimate against measurement, compound 3: 1.6-fold (0.21 log units) below; measured number inside the range.
By their numbers in this assay, from the lowest: compound 1; then compounds 3 and 2 (each within the scatter of the next).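

In this assay, methoxy in place of hydrogen on this aromatic carbon, meta to a large group, gives a 1.3-fold lower number from compound 2 to compound 3 (0.12 log units; within the scatter) and so shows no effect that can be separated from the scatter. The one-place change on the nitrogen is of a different order, with hydrogen in place of (1-bromoethenyl)carbonyl giving an 11-fold higher number from compound 1 to compound 3 (1.05 log units; beyond the scatter) as the first large step read in the series. Nothing measured here bears on the reason for either step.

Open, from the compounds shown here alone, is whether a hydroxyl group or a chlorine atom at this aromatic carbon would separate from hydrogen. Also open, going by these compounds, is whether a plain acetyl group on the nitrogen would hold the number of compound 1 2300 nM or whether the bromine is needed.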